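The source may report more compounds than this note shows. Statements on the series, on what has been measured and on what is new or still open speak of the compounds shown alone.

Compound 1, `COc1cc2c(Oc3ccc(NC(=O)c4nn(-c5ccc([N+](=O)[O-])cc5)c(=O)c5ccccc45)cc3F)ccnc2cc1OCCCN1CCCC1`: 1620 nM
Compound 2, `COc1cc2c(Oc3ccc(NC(=O)c4nn(-c5cccc(F)c5)c(=O)c5ccccc45)cc3F)ccnc2cc1OCCCN1CCC(C)CC1`: 220 nM

In a functional assay on MKN-45 cells (Homo sapiens) for cytotoxicity, read by MTT assay, with a stated time of 72 h (a higher number here means a weaker inhibitor, a lower number a stronger inhibitor), compound 2 gives the lower of the two numbers, and its gap to compound 1 lies well beyond the usual scatter. Compound 1 differs from compound 2 in more than one place, so no single step between them is shown; the two values say only that compound 1 is the weaker of the pair. Compound 3, `COc1cc2c(Oc3ccc(NC(=O)c4nn(-c5ccc([N+](=O)[O-])cc5)c(=O)c5ccccc45)cc3F)ccnc2cc1OCCCN1CCC(C)CC1`, has not been measured. It differs from compound 2 in one place: 4-nitrophenyl in place of 3-fluorophenyl on an aromatic nitrogen. Compound 1 also carries 4-nitrophenyl on that aromatic nitrogen, and compound 1 sits well above compound 2, but the second difference between compound 1 and compound 2 cannot be separated out, so only part of that gap can be laid on the aromatic nitrogen substituent. The expectation is therefore that the change from compound 2 to compound 3 raises the number by a moderate step, a 3.2-fold higher number from compound 2 to compound 3 (0.50 log units; beyond the scatter), beyond the scatter yet smaller than the whole gap to compound 1. Compound 3 is expected at 700 nM, with a likely range from 250 nM to 2000 nM.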

Compound 3, half-maximal inhibitory concentration: 1150 nM
The estimate for compound 3 lay 1.6-fold (0.22 log units) below the measured number, within the range that was stated.
By their numbers in this assay, from the lowest: compound 2; then compounds 3 and 1 (each within the scatter of the next).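

In this assay, the replacement of 3-fluorophenyl by 4-nitrophenyl on the aromatic nitrogen can now be read by itself, with 4-methylpiperidin-1-yl held constant at the end of the chain: a 5.2-fold higher number from compound 2 to compound 3 (0.72 log units; beyond the scatter). The other new step, 4-methylpiperidin-1-yl in place of pyrrolidin-1-yl with 4-nitrophenyl held constant, gives a 1.4-fold lower number from compound 1 to compound 3 (0.15 log units; within the scatter), so among these single changes only the one on the aromatic nitrogen is beyond the scatter, and the amine change shows no resolved effect in this 4-nitrophenyl series. No accompanying measurement bears on the reason for the difference at the aromatic nitrogen.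

These compounds do not separate the identity of the substituent from its place on the phenyl ring, a question that 4-fluorophenyl and 3-nitrophenyl groups on the same nitrogen would address. They also leave open whether the amine change would remain within the scatter alongside 3-fluorophenyl, and how another amine such as morpholin-4-yl would compare at the end of the chain.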